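Second chloro on the benzophenone series: expectation for compound 3

A few compounds are considered here, and "the series" means these few. Any claim that something is new, unique, unknown or untested is made for them only; others in the source may bear on it.

Measured so far in a functional assay on PANC-1 cells (Homo sapiens) for antiproliferative activity, read by MTT assay, with a stated time of 72 h; a lower number here means a stronger inhibitor, a higher number a weaker inhibitor:
- compound 1, `COc1cc(C)c(Br)c(O)c1C(=O)c1c(C=O)c(O)cc(O)c1CC=C(C)C`: 26000 nM
- compound 2, `COc1cc(C)c(Cl)c(O)c1C(=O)c1c(C=O)c(O)cc(O)c1CC=C(C)C`: 14000 nM

Among the compounds with values here, compound 2 has the lowest of the two numbers, but its only neighbour is compound 1, and the step of a 1.9-fold lower number from compound 1 to compound 2 (0.27 log units; within the scatter) lies within the scatter, so the two values cannot be ordered with confidence.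

Compound 3, `COc1c(Cl)c(C)c(Cl)c(O)c1C(=O)c1c(C=O)c(O)cc(O)c1CC=C(C)C`, is unmeasured. It differs from compound 2 by chloro in place of hydrogen on an aromatic carbon.

Within the data shown here, only one measured step exists, and it concerns a swap of one halogen for another at a carbon that already carried a halogen. Among the measured compounds shown here, no measured pair shows what a chloro entering in place of hydrogen does on this core. For the measured compounds named here, the one step that is known is small, and no basis exists for expecting a larger change from adding a second chloro. The expected step in this assay is therefore a 1.2-fold lower number from compound 2 to compound 3 (0.07 log units; within the scatter), that is, none beyond the scatter.

Compound 3 is expected to give about 12000 nM, with a range from 4000 nM to 40000 nM.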

Compound 3, half-maximal inhibitory concentration: 14000 nM
Estimate against measurement, compound 3: 1.2-fold (0.07 log units) below, and the stated range covers the measured number.
By their numbers in this assay, from the lowest: compounds 2, 3 and 1 (each within the scatter of the next).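

In this assay, within the data shown here, chloro in place of hydrogen on this aromatic carbon, ortho to a methoxy group and ortho to a methyl group, gives no change at the digits printed from compound 2 to compound 3 (within the scatter) and so supplies the only measured step on the shared core in which a halogen enters at a carbon that carried hydrogen, rather than replacing another halogen. This position therefore accepts one added chloro without a shift beyond the scatter in this read-out, even with a chloro group already standing meta to it, a point that the swap between compound 1 and compound 2 could not address. Nothing measured here bears on why the number holds at this position.

On these data alone, whether an amine, a carboxylic acid or a longer chain on this same carbon would move the number beyond the scatter remains open, and a single chloro says little about groups of another kind at this place. Also open, as far as these compounds go, is what hydrogen in place of the chloro group meta to this carbon would give, so the contribution of that group to the values of the series remains unknown.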